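This account rests on a few compounds, and the source may have more. Where it says the series, first, only, none or still open, it means among the compounds named here.

Compound 1 `CCCCNC(=O)Nc1cccc2c1CN(C)CC2c1ccccc1`: 23 mg/kg
Compound 2 `CCCCOC(=O)Nc1cccc2c1CN(C)CC2c1ccccc1`: 2.6 mg/kg

In a functional assay on the whole organism for inhibition, with Mus musculus as the target (a lower number here means that less compound is needed, a higher number that more compound is needed for the effect), compound 2 has the lower of the two numbers, at 2.6 mg/kg. Compound 3 `CN1Cc2c(NC(=O)OCc3ccccc3)cccc2C(c2ccccc2)C1` keeps its carbonyl and oxygen but differs in the chain: phenyl in place of propyl on a saturated chain carbon bound to an oxygen next to a carbonyl group. This is phenyl in place of propyl on a saturated chain carbon bound to an oxygen next to a carbonyl group. Within the data shown here, the only measured step, an 8.8-fold lower number from compound 1 to compound 2 (0.95 log units; beyond the scatter), changed butylamino to butoxy, so it shows that this assay responds to this side chain but does not test this change. No direction can be argued, and the expected result is little change, estimated as a 1.2-fold higher number from compound 2 to compound 3 (0.06 log units; within the scatter). Compound 3 is estimated at 3 mg/kg, with an expected range of 0.8 mg/kg to 11 mg/kg.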

Compound 3, dose for half-maximal effect: 16 mg/kg
The estimate for compound 3 lay 5.3-fold (0.73 log units) below the measured number; measured number above the stated range.
By their numbers in this assay, from the lowest: compound 2; then compounds 3 and 1 (each within the scatter of the next).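

In this assay, phenyl in place of propyl on a saturated chain carbon bound to an oxygen next to a carbonyl group gives a 6.2-fold higher number from compound 2 to compound 3 (0.79 log units; beyond the scatter), so this position does not accept butoxy and benzyloxy alike. The advantage of butoxy over butylamino does not carry over to benzyloxy, which gives a 1.4-fold lower number from compound 1 to compound 3 (0.16 log units; within the scatter). No measurement shown here accounts for this step. As far as these compounds go, it remains open whether a cyclohexyl group or a longer chain such as hexyl in this place would stay closer to compound 2 or to compound 3.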